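This account rests on a few compounds, and the source may have more. Where it says the series, first, only, none or still open, it means among the compounds named here.

Three compounds have been measured in a physicochemical assay for acid dissociation:

Compound 1 `COc1ccc(F)cc1CNCCCNc1ccnc2cc(C3CCCCC3)ccc12` gives 9.47.
Compound 2 `COc1ccc(-c2ccc3c(NCCCNCc4cc(F)ccc4OC)ccnc3c2)cc1` gives 9.47.
Compound 3 `COc1ccc(F)cc1CNCCCNc1ccnc2cc(CC3CCCCC3)ccc12` gives 9.47.

Compound 3 therefore stands level with compounds 1 and 2; the three values lie within the scatter of one another. Compound 4 `COc1ccc(F)cc1CNCCCNc1ccnc2cc(Oc3ccccc3OC)ccc12` is not yet measured. The change from compound 3 is 2-methoxyphenoxy in place of cyclohexylmethyl on an aromatic carbon. All three measured steps alter the same position: no change at the digits printed from compound 1 to compound 2 (within the scatter), no change at the digits printed from compound 1 to compound 3 (within the scatter), and no change at the digits printed from compound 2 to compound 3 (within the scatter). Each of those steps left the reading unchanged, so no step beyond the scatter is expected here either. This amounts to an expected step of no change at the digits printed from compound 3 to compound 4 (within the scatter). Compound 4 is expected at 9.47, with a range from 9.1 to 9.8.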

Compound 4, acid dissociation constant: 9.28
Compound 4: middle estimate off by 0.19 log units, on the high side, and the stated range covers the measured number.
By their numbers in this assay, from the lowest: compounds 4, 1, 2 and 3 (each within the scatter of the next).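

In this assay the swap to 2-methoxyphenoxy gives the first difference at the printed digits at this position: a number 0.19 log units lower from compound 3 to compound 4 (within the scatter) and a number 0.19 log units lower from compound 2 to compound 4 (within the scatter) and a number 0.19 log units lower from compound 1 to compound 4 (within the scatter). All three steps stay within the scatter, so this oxygen-bearing aromatic group reads the same in practice as cyclohexyl, 4-methoxyphenyl and cyclohexylmethyl. No supporting information bears on this small difference. Going by these compounds, whether an amine or a carboxylic acid at this position would move the number beyond the scatter remains open.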